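Furan-2-yl to furan-3-yl on the shared core

The source may hold more compounds than are shown below. What is called first, only, known or untested is meant among the compounds shown, and "the series" means these compounds.

Compound 2 `O=C1ON=C(c2cccs2)/C1=C/c1ccco1` gives 5800 nM in a functional assay on the whole organism for inhibition, with Rattus norvegicus as the target (on this read-out lower numbers stand for stronger inhibition and higher numbers for weaker inhibition), and stands highest of the two numbers in hand; its nearest neighbour, compound 1 `O=C1ON=C(c2cccs2)/C1=C/c1ccsc1`, gives 3000 nM, and the step of a 1.9-fold higher number from compound 1 to compound 2 (0.29 log units; within the scatter) lies within the scatter. Compound 3 `O=C1ON=C(c2cccs2)/C1=C/c1ccoc1` differs from compound 2 by furan-3-yl in place of furan-2-yl on a double-bonded chain carbon bound to a double-bonded ring carbon. Among the compounds with values here, the single measured step also concerns the group at this place and stayed within the scatter, but nothing in hand separates furan-2-yl from furan-3-yl directly. No step beyond the scatter is therefore expected, a 1.3-fold lower number from compound 2 to compound 3 (0.11 log units; within the scatter). Compound 3 is expected at 4500 nM, between 1800 nM and 11000 nM.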

Compound 3, half-maximal inhibitory concentration: 3600 nM
For compound 3 the middle estimate is 1.3-fold (0.10 log units) above the measured one; the range from low to high includes it.
By their numbers in this assay, from the lowest: compounds 1, 3 and 2 (each within the scatter of the next).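

In this assay, furan-3-yl in place of furan-2-yl gives a 1.6-fold lower number from compound 2 to compound 3 (0.21 log units; within the scatter), and furan-3-yl in place of thiophen-3-yl gives a 1.2-fold higher number from compound 1 to compound 3 (0.08 log units; within the scatter). With these steps, all three groups at this place on a double-bonded chain carbon bound to a double-bonded ring carbon lie within the scatter of one another, so the furan-2-yl and furan-3-yl isomers are not separated. Nothing available explains these results.

As far as these compounds go, whether an amine, a carboxylic acid or a longer chain at this place would give a step beyond the scatter stays open.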